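Acid side chain variation on the shared aniline core

This account rests on a few compounds, and the source may have more. Where it says the series, first, only, none or still open, it means among the compounds named here.

Compound 2 `O=C(O)COc1ccc(NCc2cccc(Oc3ccccc3)c2)cc1` carries a carboxymethoxy group on the shared core. In a functional assay on CHO cells for agonist activity at Free fatty acid receptor 1 (Homo sapiens) (on this read-out higher numbers stand for an effect only at larger amounts of compound and lower numbers for an effect already at smaller amounts), compound 2 gives 2040 nM, the highest of the two numbers obtained so far. The nearest is compound 1 `O=C(O)CCCc1ccc(NCc2cccc(Oc3ccccc3)c2)cc1`, which in this assay gives 1120 nM; the step of a 1.8-fold higher number from compound 1 to compound 2 (0.26 log units; within the scatter) lies within the scatter, so the two acids are not separated by this read-out.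

Compound 3 `CC(Cc1ccc(NCc2cccc(Oc3ccccc3)c2)cc1)C(=O)O` has not been measured. It differs from compound 2 as follows: 2-carboxypropyl in place of carboxymethoxy on an aromatic carbon. Going by the values given here, the only measured step that bears on this change is a 1.8-fold higher number from compound 1 to compound 2 (0.26 log units; within the scatter), which exchanged one acid-bearing group for another on the same aromatic carbon without moving the number beyond the scatter. The 2-carboxypropyl of compound 3 is closer in kind to the 3-carboxypropyl of compound 1 than to the carboxymethoxy of compound 2, and compound 1 gives 1120 nM in this assay. The expectation in this assay is therefore a small step toward lower numbers, a 2.0-fold lower number from compound 2 to compound 3 (0.31 log units; beyond the scatter), which need not exceed the scatter. Compound 3 is estimated at 1000 nM, with a range from 300 nM to 3500 nM.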

Compound 3, half-maximal effective concentration: 100 nM
Compound 3: middle estimate off by 10-fold (1.00 log units), on the high side; the whole stated range lies above it.
By their numbers in this assay, from the lowest: compound 3; then compounds 1 and 2 (each within the scatter of the next).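

Working notes: the acid side chain at this position, on an aromatic carbon para to a large group, is not indifferent to change in this assay. The earlier exchange, a 1.8-fold higher number from compound 1 to compound 2 (0.26 log units; within the scatter), suggested a flat response, but 2-carboxypropyl in place of carboxymethoxy gives a 20-fold lower number from compound 2 to compound 3 (1.31 log units; beyond the scatter). The smaller structural change of 1-carboxyethyl in place of 2-carboxyethyl on a saturated chain carbon bound to an aromatic carbon gives an 11-fold lower number from compound 1 to compound 3 (1.05 log units; beyond the scatter), so the absence of the carboxymethoxy group does not by itself account for the drop, as compound 1 lacks that group too and stays within the scatter of compound 2. No measurement here offers an explanation for this large step.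

The compounds shown do not tell whether a larger group such as ethyl on the same chain carbon as the methyl of compound 3 would carry the trend further, or whether a longer chain with the same branch would keep it. They also leave open whether a tetrazole could stand in place of the carboxylic acid on the 2-carboxypropyl chain.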